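The compounds below may be only part of what the source reports. "The series", "measured", "known", "first", "only" and "open" are said of these compounds alone.

Compound 1 `CC(C)(C)c1ccc(-c2noc(-c3ccc(C4=NCCN4)cc3)n2)cc1` — 411 nM
Compound 2 `Clc1ccccc1-c1noc(-c2ccc(C3=NCCN3)cc2)n1` — 30 nM
Compound 3 `COc1ccc(-c2noc(-c3ccc(C4=NCCN4)cc3)n2)cc1OC` — 756 nM

All three compounds share one core and differ only in the substituents on the outer benzene ring. In an assay for inhibition of Amine oxidase [flavin-containing] B (Homo sapiens), read by fluorescence and spectrophotometry, using microsomes, with stated times of 30 min and 20 min (on this read-out lower numbers stand for stronger inhibition and higher numbers for weaker inhibition), compound 1 gives 411 nM, the second highest of the three numbers. Its nearest neighbour is compound 3, which gives 756 nM in this assay; these two values lie within the scatter of each other, so nothing can be said about which is the stronger inhibitor. Compound 2, with 30 nM in this assay, is the furthest away: its number is lower than that of compound 1 by a margin beyond the scatter.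

Compound 4 `c1ncn(Cc2ccc(-c3noc(-c4ccc(C5=NCCN5)cc4)n3)cc2)n1` has not yet been measured. The change from compound 1 is (1H-1,2,4-triazol-1-yl)methyl in place of tert-butyl on an aromatic carbon. Within the data shown here, no measured pair shows this particular exchange, so there is no direct guide to its size. Compound 1 and compound 3 both carry substituents on the same ring and give similar numbers, which suggests that another exchange there may move the value only modestly. The step from compound 1 to compound 4 is expected to be a 1.5-fold higher number from compound 1 to compound 4 (0.16 log units; within the scatter), a small rise, with considerable uncertainty in both directions. Compound 4 is therefore estimated at 600 nM in this assay, with a range from 150 nM to 3000 nM.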

Compound 4, half-maximal inhibitory concentration: 9020 nM
Beside the measured number, compound 4's estimate is 15-fold (1.18 log units) below it; measured number above the stated range.
By their numbers in this assay, from the lowest: compound 2; then compounds 1 and 3 (each within the scatter of the next); then compound 4.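

In this assay, replacing tert-butyl with (1H-1,2,4-triazol-1-yl)methyl gives a 22-fold higher number from compound 1 to compound 4 (1.34 log units; beyond the scatter), a large loss of inhibition from a change at a single place. Among these compounds, this is the first measured pair that differs in one place only, and it shows that the aromatic carbon para to a large group does not tolerate every substituent: exchanging one group there can move the number well beyond the usual scatter. Nothing given here explains the size of this step, as no measurement bears on its cause.

The exchange alters several things at once, since the entering group has more heavy atoms, contains nitrogen and carries an aromatic ring, so this single step cannot show which of these features matters. As far as these compounds go, a benzyl group, with a ring of carbon only on the same one-carbon link, or a dimethylaminomethyl group, with a nitrogen but no ring, would help to separate them, and how either would compare with compound 1 and compound 4 remains open.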